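The compounds below may be only part of what the source reports. "The series", "measured", "known", "first", "only" and "open" are said of these compounds alone.

Compound 1 `Oc1ccc(CNc2ncnc3c2ncn3C2CCCCO2)cc1`: > 100000 nM
Compound 2 `COc1cc(CNc2ncnc3c2ncn3C2CCCCO2)ccc1O`: > 100000 nM
Compound 3 `COc1ccc(OC)c(CNc2ncnc3c2ncn3C2CCCCO2)c1`: 25400 nM

In an ADME assay on MCF7 cells (Homo sapiens) for cytotoxicity, with a stated time of 72 h (a higher number here means a weaker inhibitor, a lower number a stronger inhibitor), compound 1 gives > 100000 nM as a limit of the assay and not a number. Compound 2 gives > 100000 nM as a limit too. For the measured compounds named here, compound 3 gives 25400 nM as the only true number in the set. Compound 1 thus stands at the limit of > 100000 nM in this assay, at which 2 of the 3 values shown sit, and has no readable value of its own.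

Compound 4 `Oc1cccc(CNc2ncnc3c2ncn3C2CCCCO2)c1O` is the next to be tested in this assay and departs from compound 1 by 2,3-dihydroxyphenyl in place of 4-hydroxyphenyl on a saturated chain carbon bound to a nitrogen on an aromatic ring with the shared core left as it is. Going by the values given here, the one measured step that bears on this change is a step that the two limits leave unreadable from compound 1 to compound 2 and it offers no size to carry over. Among the compounds with values here, the only guide to a reachable number is compound 3 at 25400 nM and its substituents differ from those of compound 4. A modest move toward stronger inhibition is therefore expected, and compound 4 may well be reported only as a limit again. The expected change is an at least 1.4-fold lower number from compound 1 to compound 4 (0.15 log units; that floor lies within the scatter) and it is a loose expectation. For compound 4 the estimate is 70000 nM and the expected range runs from 20000 nM to 120000 nM in this assay.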

Compound 4, half-maximal inhibitory concentration: > 100000 nM
Compound 4: only a limit was reported; the forecaster's own chance of this, stated with the estimate: 55%; middle value at least 1.4-fold (0.15 log units) away from the limit.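

In this assay, for the compounds shown here, compound 4 gives > 100000 nM, a limit of the assay and not a number, and compound 1 is also reported only as a limit, so no step between compound 1 and compound 4 can be read. Compound 4 thus stands at the shared ceiling: the limit of > 100000 nM in this assay, at which 3 of the 4 values shown sit.

The compounds shown leave open whether 2,3-dihydroxyphenyl and 4-hydroxyphenyl differ at all in this assay.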